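This account rests on a few compounds, and the source may have more. Where it says the series, first, only, none or still open, it means among the compounds named here.

Measured so far:
- compound 1 `COc1cc(C(=O)N/N=C/c2ccc(F)c(F)c2)cc(OC)c1OC`: 35.1%
- compound 2 `COc1cc(C(=O)N/N=C/c2cccc(F)c2)cc(OC)c1OC`: 53.5%
- compound 3 `COc1cc(C(=O)N/N=C/c2ccc(F)cc2)cc(OC)c1OC`: 76%

All three share one core and differ only in the fluorine pattern on the ring attached to the carbon with a double bond to nitrogen. In a functional assay on PC-3 cells (Homo sapiens) for antiproliferative activity, read by MTT assay, tested at 1 uM (on this read-out higher numbers stand for a stronger effect at the one concentration tested and lower numbers for a weaker effect), compound 3 gives the highest number of the three, with a number 22.5 percentage points higher from compound 2 to compound 3 (beyond the scatter) and a number 40.9 percentage points higher from compound 1 to compound 3 (beyond the scatter) both beyond the scatter.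

Compound 4 `COc1cc(C(=O)N/N=C/c2cc(Cl)cc(Cl)c2)cc(OC)c1OC` carries a different ring there: 3,5-dichlorophenyl in place of 4-fluorophenyl on a carbon with a double bond to nitrogen. Among the measured compounds shown here, no measured step involves chlorine, so the nearest guides are a number 22.5 percentage points higher from compound 2 to compound 3 (beyond the scatter) and a number 40.9 percentage points higher from compound 1 to compound 3 (beyond the scatter), which show that moving or adding substituents away from the 4-position lowered the number. A step downward of a number 34 percentage points lower from compound 3 to compound 4 (beyond the scatter) is therefore expected, with wide uncertainty.

Compound 4 is estimated at 42%, between 20% and 65%.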

Compound 4, a percentage reported as inhibition, at one concentration (the size of the read-out at that concentration, not a potency): 22.1%
Beside the measured number, compound 4's estimate is 19.9 percentage points above it; the measured number falls inside the stated range.
By their numbers in this assay, from the lowest: compound 4; then compound 1; then compound 2; then compound 3.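

In this assay the 3,5-dichlorophenyl ring of compound 4 sets a new floor at this position, with a number 53.9 percentage points lower from compound 3 to compound 4 (beyond the scatter) and a number 31.4 percentage points lower from compound 2 to compound 4 (beyond the scatter) and even a number 13 percentage points lower from compound 1 to compound 4 (beyond the scatter) as the smallest of the three drops. Chlorine on this ring thus gives a lower number than any of the three fluorine patterns shown, all these steps lying beyond the scatter. No measurement here accounts for the fall. On these data alone, compound 4 differs from the others in both its halogen and its substitution pattern, so which of the two matters stays open. As far as these compounds go, how an amine or a carboxylic acid on this ring would read also remains unknown.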